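The source may hold more compounds than are shown below. What is called first, only, known or untested is meant among the compounds shown, and "the series" means these compounds.

Measured compounds:

Compound 1, `O=C(Nc1ccc(NCc2cccc(C(F)(F)F)c2)cc1Cl)c1cc(Cl)ccc1O`, gives 13300 nM in an ADME assay on A549 cells (Homo sapiens) for cytotoxicity, read by resazurin assay, with a stated time of 48 h; on this read-out lower numbers stand for higher toxicity in this test and higher numbers for lower toxicity in this test.
Compound 2, `O=C(Nc1ccc(NCc2cc(Cl)cc(C(F)(F)F)c2)cc1Cl)c1cc(Cl)ccc1O`, gives 30900 nM in this assay.
Compound 3, `O=C(Nc1ccc(NC2CCCC2)cc1)c1cc(Cl)ccc1O`, gives 10000 nM in this assay.

Compound 1 and compound 2 differ in one place: chloro in place of hydrogen on an aromatic carbon. This change produced a 2.3-fold higher number from compound 1 to compound 2 (0.37 log units; beyond the scatter), a shift toward lower toxicity in this test. Compound 4, `O=C(Nc1ccc(NC2CCCC2)c(Cl)c1)c1cc(Cl)ccc1O`, is not yet measured. It relates to compound 3 in the same kind of way: chloro in place of hydrogen on an aromatic carbon. The surroundings of the place are not identical, though: in the earlier pair the entering chloro sits meta to a trifluoromethyl group, whereas in compound 4 it sits ortho to a cyclopentylamino group, so the two changes are of the same kind rather than the same. How the core of compound 3 differs from the core of compound 1 is not broken down here; their values in this assay lie within the scatter of each other.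

For compound 4 in this assay a step of a 1.7-fold higher number from compound 3 to compound 4 (0.23 log units; within the scatter) is expected, somewhat smaller than the one seen because a 2.3-fold higher number from compound 1 to compound 2 (0.37 log units; beyond the scatter) came from a place with different neighbours. Compound 4 is therefore estimated at 17000 nM, with a range from 8000 nM to 40000 nM.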

Compound 4, half-maximal cytotoxic concentration: 16900 nM
Compound 4: middle estimate off by 1.0-fold (0.00 log units), on the high side, within the range that was stated.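

In this assay, chloro in place of hydrogen on an aromatic carbon of compound 3 gives a 1.7-fold higher number from compound 3 to compound 4 (0.23 log units; within the scatter), so this step alone cannot be told apart from the normal variation between repeated measurements. Two pairs are a small basis, and the entering chloro has different neighbours in each, so they do not show that the change has a fixed size across this series or explain why it acts as it does. What they do show is that the size of the step carries over from one core to the other as closely as these measurements can tell: the same change on two cores in this assay, a 2.3-fold higher number (0.37 log units; beyond the scatter) from compound 1 to compound 2 and a 1.7-fold higher number (0.23 log units; within the scatter) from compound 3 to compound 4, 1.4-fold (0.14 log units) apart, within the scatter of two such steps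

The compounds shown leave open whether a fluoro or a methyl group in the place taken by chloro would give a similar step on the core of compound 3. They also leave open whether the chloro step would hold if a carboxylic acid or a longer chain replaced the cyclopentylamino group.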